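From 3-oxomorpholin-4-yl to 3-methoxyazetidin-1-yl: clearance notes

The source may hold more compounds than are shown below. What is called first, only, known or untested is meant among the compounds shown, and "the series" means these compounds.

In an ADME assay on microsomes from liver (Mus musculus) for metabolic stability, read by LC-MS, using NADPH, with stated times of 10 min and 30 min, tested at 1 uM (a lower number here means slower removal, a higher number faster removal of the compound), compound 1 `COC(=O)C1=C(C)NC(c2nccs2)=NC1(C)c1ccc(Cl)cc1` gives 85 mL/min/kg and compound 2 `COC(=O)C1=C(CN2CCOCC2=O)NC(c2nccs2)=NC1(C)c1ccc(F)cc1` gives 80 mL/min/kg with the two numbers lying within the usual scatter of each other. Compound 2 therefore cannot be separated from compound 1 on this read-out, and both numbers stand as the only reference points so far.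

The next structure is compound 3 `COC(=O)C1=C(CN2CC(OC)C2)NC(c2nccs2)=NC1(C)c1ccc(F)cc1` with the change 3-methoxyazetidin-1-yl in place of 3-oxomorpholin-4-yl on a saturated chain carbon bound to a double-bonded ring carbon on the otherwise unchanged compound 2 framework. The swap puts 3-methoxyazetidin-1-yl in place of 3-oxomorpholin-4-yl on a saturated chain carbon bound to a double-bonded ring carbon.

Among the compounds with values here, no measured pair differs in one place only, so this change has no direct precedent in this assay and no direction can be argued from the data. No step beyond the scatter is expected. That expectation rests only on compound 1 at 85 mL/min/kg and compound 2 at 80 mL/min/kg as the measured level of the series.

The expected move is small, namely a 1.1-fold lower number from compound 2 to compound 3 (0.03 log units; within the scatter) as an estimate. The estimated clearance of compound 3 is 75 mL/min/kg with an expected range from 45 mL/min/kg to 110 mL/min/kg as the working window.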

Compound 3, clearance: 88 mL/min/kg
For compound 3 the middle estimate is 1.2-fold (0.07 log units) below the measured one, and the stated range covers the measured number.
By their numbers in this assay, from the lowest: compounds 2, 1 and 3 (each within the scatter of the next).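

In this assay, within the data shown here, the exchange of 3-oxomorpholin-4-yl for 3-methoxyazetidin-1-yl on a saturated chain carbon bound to a double-bonded ring carbon gives a 1.1-fold higher number from compound 2 to compound 3 (0.04 log units; within the scatter) and provides the first pair that differs in one place only. At this position, then, a six-membered non-aromatic ring with 2 hetero atoms and a carbonyl can give way to a four-membered non-aromatic ring with 1 hetero atom and a methoxy group without a step that can be separated from the scatter of this read-out. No measured evidence at hand accounts for this result, so the pair records the outcome without explaining it.

The two groups compared here are both attached through a ring nitrogen and carry no net charge, so the compounds shown leave open whether a primary amine, a carboxylic acid or a longer chain at this position would give a step beyond the scatter. The pair also leaves open whether any group at this place would bring the clearance out of the scatter of compound 2, and steps to compound 1 cannot be read as it differs from compound 2 and compound 3 in more than one place.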